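Notes on one aromatic group exchange in the series

The source may report more compounds than this note shows. Statements on the series, on what has been measured and on what is new or still open speak of the compounds shown alone.

In an ADME assay on microsomes from liver (Homo sapiens) for metabolic stability (on this read-out higher numbers stand for fast clearance and lower numbers for slow clearance), compound 2 (`Cn1ncc(-c2nn(C)c3ncnc(N4CCC4)c23)c1-c1ccc(C(F)(F)F)cn1`) gives 33 mL/min/kg. Within the data shown here, the only other measured member, compound 1 (`CCc1ccc(-c2c(-c3nn(C)c4ncnc(N5CC(NC(=O)OC)C5)c34)cnn2C)cc1`), gives 42 mL/min/kg. These two values lie within the usual scatter of each other, so compound 2 cannot be separated from compound 1 on this read-out.

The next member, compound 3 (`Cn1ncc(-c2nn(C)c3ncnc(N4CCC4)c23)c1-c1ccc(C2CC2)cc1`), has 4-cyclopropylphenyl in place of 5-(trifluoromethyl)pyridin-2-yl on an aromatic carbon of a five-membered aromatic ring with 2 nitrogen. The counted difference is as follows: 4-cyclopropylphenyl in place of 5-(trifluoromethyl)pyridin-2-yl on an aromatic carbon. Among the measured compounds shown here, no measured step isolates this exchange, so the data give neither its size nor its direction.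

The expectation therefore rests on two values only, and it stays close to them. In this assay, no change beyond the scatter is expected, with a slight lean towards faster clearance. The expected step is a 1.3-fold higher number from compound 2 to compound 3 (0.10 log units; within the scatter), and this is a cautious estimate rather than a trend. For compound 3 the estimated clearance is 42 mL/min/kg, with an expected range of 22 mL/min/kg to 75 mL/min/kg.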

Compound 3, clearance: 90 mL/min/kg
The estimate for compound 3 lay 2.1-fold (0.33 log units) below the measured number; measured number above the stated range.
By their numbers in this assay, from the lowest: compounds 2 and 1 (each within the scatter of the next); then compound 3.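

In this assay, 4-cyclopropylphenyl in place of 5-(trifluoromethyl)pyridin-2-yl on an aromatic carbon of the five-membered aromatic ring with 2 nitrogen gives a 2.7-fold higher number from compound 2 to compound 3 (0.44 log units; beyond the scatter), so the group at this position can move clearance beyond the scatter while the rest of compound 2 stays unchanged. This single step is also the first direction available for the position: among these two groups, the higher number goes with 4-cyclopropylphenyl, although the exchange removes the ring nitrogen and the trifluoromethyl group and adds the cyclopropyl group all at once, so the step cannot assign the change to any one of these parts. No measurement available here bears on the cause of the step.

As far as these compounds go, what remains open is whether the ring nitrogen or the group on the aromatic ring carries the step, a question that a phenyl ring bearing trifluoromethyl and a pyridine ring bearing cyclopropyl would separate. From the compounds shown here alone, compound 1 differs from compound 2 and compound 3 in more than one place, so it says nothing about this exchange, and the reach of the step to other members stays unknown.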